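Sulfonamide heteroaryl swap in a chromone-imidazolone series

This account rests on a few compounds, and the source may have more. Where it says the series, first, only, none or still open, it means among the compounds named here.

Compound 1 `O=C1/C(=C/c2coc3ccccc3c2=O)N=C(c2ccc(Cl)cc2)N1c1ccc(S(=O)(=O)Nc2ncccn2)cc1` carries pyrimidin-2-yl on the sulfonamide nitrogen; in a functional assay on A549 cells (Homo sapiens) for cytotoxicity, read by sulforhodamine B assay, with a stated time of 72 h (on this read-out lower numbers stand for stronger inhibition and higher numbers for weaker inhibition), compound 1 gives 59000 nM. Compound 2 `Cc1cc(NS(=O)(=O)c2ccc(N3C(=O)/C(=C/c4coc5ccccc5c4=O)N=C3c3ccc(Cl)cc3)cc2)no1` carries 5-methyl-1,2-oxazol-3-yl at the same place. In this assay compound 2 gives only a limit, > 100000 nM. Compound 2 therefore sits at the weak end of what was measured, as noted in the limit of > 100000 nM in this assay, at which 1 of the 2 values shown sits. Within the data shown here, the one measured step, an at least 1.6-fold higher number from compound 1 to compound 2 (0.22 log units; that floor lies within the scatter), is the only comparison that bears on the sulfonamide substituent.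

Compound 3 `O=C1/C(=C/c2coc3ccccc3c2=O)N=C(c2ccc(Cl)cc2)N1c1ccc(S(=O)(=O)Nc2ccccn2)cc1` differs from compound 2 by pyridin-2-yl in place of 5-methyl-1,2-oxazol-3-yl on a sulfonamide nitrogen. Pyridin-2-yl resembles the pyrimidin-2-yl of compound 1 more closely than the oxazole does, so compound 3 is expected to return toward the value of compound 1, 59000 nM, a lowering in this assay of roughly an at least 1.4-fold lower number from compound 2 to compound 3 (0.15 log units; that floor lies within the scatter), which may not exceed the scatter. Compound 3 is estimated at 70000 nM, within 30000 nM to 200000 nM.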

Compound 3, half-maximal inhibitory concentration: > 100000 nM
Compound 3 ended at the assay's limit (the forecaster's own chance of this, stated with the estimate: 40%); at least 1.4-fold (0.15 log units) between middle value and limit.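

Pyridin-2-yl on the sulfonamide nitrogen gives an at least 1.6-fold higher number from compound 1 to compound 3 (0.22 log units; that floor lies within the scatter), so a six-membered aromatic ring with 1 hetero atom does not by itself keep a readable value in this assay. The step from compound 2 to compound 3 cannot be read, as both values are limits. Of the three groups shown at this place, only pyrimidin-2-yl gives a number rather than a limit, and the limit now covers both a five-membered and a six-membered ring: the limit of > 100000 nM in this assay, at which 2 of the 3 values shown sit.

As far as these compounds go, whether compound 1 truly differs from compound 2 or compound 3 stays open, since neither readable floor clears the scatter and the true values behind the limits are unknown. Also open, from the compounds shown here alone, is what a plain phenyl ring, or a chain ending in an amine or a carboxylic acid, would give on this sulfonamide nitrogen.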